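Fluoro in Place of Bromo on an Inactive Anilide

The source may report more compounds than this note shows. Statements on the series, on what has been measured and on what is new or still open speak of the compounds shown alone.

Of the compounds shown here, two that share one core have been measured in a functional assay on HL-60 cells (Homo sapiens), read by calcium flux; on this read-out lower numbers stand for an effect already at smaller amounts and higher numbers for an effect only at larger amounts of compound. Compound 1 `COc1cccc(Cc2cc(C3CCCCC3)nn(CC(=O)Nc3ccc(Br)cc3)c2=O)c1` carries a cyclohexyl group on the core; in this assay compound 1 gives > 50000 nM, which is a limit of the assay and not a number. Compound 2 `COc1cccc(Cc2cc(-c3ccccc3)nn(CC(=O)Nc3ccc(Br)cc3)c2=O)c1` has a phenyl in place of that cyclohexyl on an aromatic carbon; in this assay compound 2 gives > 50000 nM, again a limit rather than a number. The step that the two limits leave unreadable from compound 1 to compound 2 is therefore unreadable. Compound 2 thus stands at the limit, and both values shown sit there (the limit of > 50000 nM in this assay, at which 2 of the 2 values shown sit).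

Compound 3 `COc1cccc(Cc2cc(-c3ccccc3)nn(CC(=O)Nc3ccc(F)cc3)c2=O)c1` differs from compound 2 only by fluoro in place of bromo on an aromatic carbon. Within the data shown here, no measured step touches this position, and the single measured step is itself unreadable, so no size can be carried over. The expectation for compound 3 is that it, too, shows no effect within the tested range, the estimated step of a number no higher from compound 2 to compound 3 (the limit leaves the size open) being essentially none. Compound 3 is estimated at 50000 nM, with a range from 20000 nM to 100000 nM.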

Compound 3, half-maximal effective concentration: > 50000 nM
Compound 3 ended at the assay's limit; the forecaster's own chance of this, stated with the estimate: 85%; the middle value sits exactly at the limit.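

In this assay compound 3 gives > 50000 nM, which is a limit of the assay and not a number. The step between compound 2 and compound 3 therefore cannot be read, and all three compounds rest at one limit: the limit of > 50000 nM in this assay, at which 3 of the 3 values shown sit.

The compounds shown leave open whether any change to this shared core gives a measurable effect in this assay.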